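A few compounds are considered here, and "the series" means these few. Any claim that something is new, unique, unknown or untested is made for them only; others in the source may bear on it.

Compound 1 `COc1cccc(N2CCN(C(=O)C(C)N3C(=O)CCC3=O)CC2)c1` gives 0% in a functional assay on the whole organism (strain Swiss) with Mus musculus as the target, in the maximal electroshock model, with a stated time of 2 h, at a dose of 100 mg/kg by the intraperitoneal route; a lower number here means a weaker effect, a higher number a stronger effect of the compound at the dose given.
Compound 2 `CC(C(=O)N1CCN(c2ccc(Cl)cc2)CC1)N1C(=O)CCC1=O` gives 0%.
Compound 3 `CC(C(=O)N1CCN(c2cccc(C(F)(F)F)c2)CC1)N1C(=O)CCC1=O` gives 0%.

Compound 3 stands level with compound 1 and compound 2 in this assay, with no difference beyond the scatter among the three. Compound 4 `CC(C(=O)N1CCN(c2cccc(Cl)c2)CC1)N1C(=O)CCC1=O` differs from compound 3 by chloro in place of trifluoromethyl on an aromatic carbon. For the measured compounds named here, two measured steps bear on this change, both on the same aromatic ring of the shared core: no change at the digits printed from compound 1 to compound 2 (within the scatter) and no change at the digits printed from compound 1 to compound 3 (within the scatter). Going by the values given here, neither step moved the read-out, and no measured step exchanges chloro for trifluoromethyl directly. The expectation for compound 4 is therefore no step beyond the scatter, no change at the digits printed from compound 3 to compound 4 (within the scatter). Compound 4 is estimated at 0%, with a range from 0% to 12%.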

Compound 4, a percentage reported as activity, at one dose (the size of the read-out at that dose, not a potency): 0%
Beside the measured number, compound 4's estimate shows no gap at the digits printed; the measured number falls inside the stated range.
By their numbers in this assay, from the lowest: compounds 1, 2, 3 and 4 (each within the scatter of the next).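

At this place on the aromatic ring, meta to a large group, chloro in place of trifluoromethyl gives no change at the digits printed from compound 3 to compound 4 (within the scatter) in this assay and so adds a third group that leaves the read-out where it was. Neither the site of the chlorine nor the exchange with methoxy registers either, with 3-chlorophenyl in place of 4-chlorophenyl giving no change at the digits printed from compound 2 to compound 4 (within the scatter) and chloro in place of methoxy giving no change at the digits printed from compound 1 to compound 4 (within the scatter). No evidence is available to account for this flat result.

From the compounds shown here alone, whether an amine or a carboxylic acid on this ring, or a longer chain on the shared core, would lift the read-out remains open. So does whether these four compounds would separate at another dose or time.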